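Furan for thiophene on the pendant five-membered ring

The source may hold more compounds than are shown below. What is called first, only, known or untested is meant among the compounds shown, and "the series" means these compounds.

Two analogues of the shared core have been measured. Compound 1 `Fc1ccc(N2CCN(CCCc3c[nH]c4ccc(F)cc34)CC2)c(-c2cn[nH]c2)c1` gives 0.9 nM in an assay on CHO cells for displacement of a labelled ligand from 5-hydroxytryptamine receptor 7 (Homo sapiens), read by scintillation counting, with a stated time of 120 min; a higher number here means a weaker inhibitor, a lower number a stronger inhibitor. Compound 2 `Fc1ccc(N2CCN(CCCc3c[nH]c4ccc(F)cc34)CC2)c(-c2ccsc2)c1` gives 2 nM in this assay. The step of a 2.2-fold higher number from compound 1 to compound 2 (0.35 log units; beyond the scatter) is the only one recorded, so compound 2 stands with the highest of the two numbers, its nearest neighbour being compound 1.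

Compound 3 `Fc1ccc(N2CCN(CCCc3c[nH]c4ccc(F)cc34)CC2)c(-c2ccoc2)c1` is the next member; the change from compound 2 is furan-3-yl in place of thiophen-3-yl on an aromatic carbon. Within the data shown here, the one step that bears on it is the exchange of the five-membered ring in the same place, a 2.2-fold higher number from compound 1 to compound 2 (0.35 log units; beyond the scatter), which was modest though beyond the scatter. Swapping one heteroatom of that ring for another is expected to move the number by a comparable or smaller amount, and the direction is not fixed by the two values in hand.

Compound 3 is therefore estimated at 2.5 nM in this assay, within 1 nM to 6 nM, meaning an expected step of a 1.3-fold higher number from compound 2 to compound 3 (0.10 log units; within the scatter) that likely stays within the scatter.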

Compound 3, inhibition constant: 11 nM
For compound 3 the middle estimate is 4.4-fold (0.64 log units) below the measured one; measured number above the stated range.
By their numbers in this assay, from the lowest: compound 1; then compound 2; then compound 3.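

Working notes on the pendant ring: in this assay, exchanging the ring sulfur of thiophen-3-yl for oxygen gives a 5.5-fold higher number from compound 2 to compound 3 (0.74 log units; beyond the scatter), although the two groups match in heavy atom count, donor and acceptor counts and net charge. This position, on an aromatic carbon ortho to a large group, therefore distinguishes two five-membered aromatic rings that those counts do not separate, and the identity of the single ring hetero atom alone moves the number beyond the scatter. Across the three rings the spread now reaches a 12-fold higher number from compound 1 to compound 3 (1.09 log units; beyond the scatter), so the choice of ring here matters more than the first pair suggested, and nothing available explains the loss on going to furan-3-yl.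

The three compounds do not show whether attachment through the other ring carbon, as in furan-2-yl or thiophen-2-yl, changes the sulfur and oxygen difference. They also leave open whether a six-membered ring such as phenyl or pyridyl, or a smaller group such as an amine or methoxy, at this carbon would bring the number back towards that of compound 1.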